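From isopropyl to phenyl on the amide carbonyl

The source may hold more compounds than are shown below. What is called first, only, known or untested is meant among the compounds shown, and "the series" means these compounds.

For the measured compounds named here, in a functional assay on B16 cells (Mus musculus) for inhibition (a lower number here means a stronger inhibitor, a higher number a weaker inhibitor), compound 1 `COc1cc(/C=C/C(=O)c2cccc(N)c2)ccc1O` gives 11.5 ug/mL, while compound 2 `COc1cc(/C=C/C(=O)c2cccc(NC(=O)C(C)C)c2)ccc1O` gives 1.09 ug/mL, the lower of the two numbers measured so far. Compound 3 `COc1cc(/C=C/C(=O)c2cccc(NC(=O)c3ccccc3)c2)ccc1O` differs from compound 2 at one place: phenyl in place of isopropyl on a carbonyl carbon. This puts phenyl in place of isopropyl on a carbonyl carbon, so that isopropylcarbonyl becomes benzoyl.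

Going by the values given here, only one measured step bears on this change: an 11-fold lower number from compound 1 to compound 2 (1.02 log units; beyond the scatter), a large step that came with isopropylcarbonyl in place of hydrogen on a nitrogen on an aromatic ring. Among the compounds with values here, that step does not show how the number responds when one group on the carbonyl carbon replaces another, and no measured pair tests such an exchange. Compound 3 keeps the carbonyl on that nitrogen, so it is expected to stay much closer to compound 2 than to compound 1, with a slight rise at most and the direction uncertain. The expected change is a 1.4-fold higher number from compound 2 to compound 3 (0.14 log units; within the scatter), which would be far smaller than the measured step. For compound 3, the estimated value is 1.5 ug/mL, with an expected range of 0.5 ug/mL to 5 ug/mL.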

Compound 3, half-maximal inhibitory concentration: 0.82 ug/mL
Compound 3: middle estimate off by 1.8-fold (0.26 log units), on the high side; low and high end bracket the measured number.
By their numbers in this assay, from the lowest: compounds 3 and 2 (each within the scatter of the next); then compound 1.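

In this assay the exchange on the carbonyl carbon comes with a 1.3-fold lower number from compound 2 to compound 3 (0.12 log units; within the scatter) and so leaves compound 2 and compound 3 indistinguishable: at this place, isopropyl with no ring and phenyl with its six-membered aromatic ring read alike, which the earlier pair could not show. The large step seen on acylating the nitrogen also recurs with a second group, since a 14-fold lower number from compound 1 to compound 3 (1.15 log units; beyond the scatter) stands alongside an 11-fold lower number from compound 1 to compound 2 (1.02 log units; beyond the scatter), so among these three compounds the lower number is not tied to isopropylcarbonyl alone. Nothing available here accounts for the two groups on the carbonyl carbon reading alike.

The compounds shown leave open how far this tolerance extends, for instance to a methyl group, a longer chain or a cyclohexyl ring on the carbonyl carbon, or to a phenyl ring carrying a methoxy group or a chlorine atom. They also leave open whether a group ending in an amine or a carboxylic acid would fit this pattern or break it.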